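The source may hold more compounds than are shown below. What is called first, only, known or untested is meant among the compounds shown, and "the series" means these compounds.

In a functional assay on NCI-H460 cells (Homo sapiens) for inhibition, read by MTT assay, with a stated time of 48 h (on this read-out lower numbers stand for stronger inhibition and higher numbers for weaker inhibition), compound 1 (`O=C(CC(c1ccccc1)C(C(=O)Nc1ccccn1)C(=O)Nc1ccccn1)c1ccccc1`) is recorded as "not active" (no number reported) and so has no single number to stand on. Compound 3 (`O=C(CC(c1ccc(F)cc1)C(C(=O)Nc1ccccn1)C(=O)Nc1ccccn1)c1ccccc1`) is likewise recorded as "not active" (no number reported) without a number. Of the measured compounds, only compound 2 (`O=C(CC(c1ccc(Cl)cc1)C(C(=O)Nc1ccccn1)C(=O)Nc1ccccn1)c1ccccc1`) has a number, at 18900 nM in this series.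

Compound 4 (`O=C(CC(c1ccccc1)C(C(=O)Nc1ccccn1)C(=O)Nc1ccccn1)c1ccc(F)cc1`) differs from compound 1 in one place, where benzoyl becomes (4-fluorophenyl)carbonyl. This is fluoro in place of hydrogen on an aromatic carbon, para to a large group. Going by the values given here, no two measured compounds differ in one place, so this change has no direct precedent in the data.

In this assay only a small step is expected, towards stronger inhibition if any number appears at all. Among the compounds with values here, the only guide to its scale is compound 2 at 18900 nM as a measured level. Compound 4 may equally well show no number. If a number is reported, compound 4 is estimated at 25000 nM with an expected range from 10000 nM to 60000 nM in this read-out.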

Compound 4, half-maximal inhibitory concentration: "not active" (no number reported)
For compound 4 the study gives words and no number, and the estimate cannot be compared.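

In this assay compound 1 and compound 4 both stand without a number, so no step can be read between them. No evidence on hand bears on this result. The compounds shown leave open whether (4-fluorophenyl)carbonyl in place of benzoyl changes inhibition at all.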